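Aryl urea series, terminal phenyl substitution

This account rests on a few compounds, and the source may have more. Where it says the series, first, only, none or still open, it means among the compounds named here.

Measured compounds:
compound 1 `COc1cc2cc(Oc3ccc(NC(=O)Nc4cccc(C(F)(F)F)c4)cc3)c(C)nc2cc1OC`, 36000 nM
compound 2 `COc1cc2cc(Oc3ccc(NC(=O)Nc4ccc(Cl)c(C(F)(F)F)c4)cc3)c(C)nc2cc1OC`, 23500 nM

In a functional assay on OVCAR-4 cells (Homo sapiens) for inhibition, read by sulforhodamine B assay, with a stated time of 48 h (a higher number here means that more compound is tolerated, a lower number that less compound is tolerated), compound 2 gives 23500 nM, the lowest of the two numbers. Compound 1 gives 36000 nM in this assay, and the step of a 1.5-fold lower number from compound 1 to compound 2 (0.19 log units; within the scatter) is within the scatter, so compound 1 and compound 2 cannot be told apart on these numbers.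

Compound 3 `COc1cc2cc(Oc3ccc(NC(=O)Nc4ccc(Cl)c(Cl)c4)cc3)c(C)nc2cc1OC` has not been measured. It differs from compound 2 in one place: chloro in place of trifluoromethyl on an aromatic carbon. Going by the values given here, no measured step covers this exchange; the only step on record, from compound 1 to compound 2, changes another position and is within the scatter. There is therefore nothing in the data that argues for a step beyond the scatter in this assay in either direction. The number for compound 3 is expected close to that of compound 2, with the step of a 1.1-fold higher number from compound 2 to compound 3 (0.03 log units; within the scatter) an estimate only. Compound 3 is estimated at 25000 nM, range 10000 nM to 60000 nM.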

Compound 3, concentration lethal to 50% of the cells: 35200 nM
Compound 3: middle estimate off by 1.4-fold (0.15 log units), on the low side, within the range that was stated.
By their numbers in this assay, from the lowest: compounds 2, 3 and 1 (each within the scatter of the next).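

In this assay the exchange at this position, ortho to a chloro group, gives a 1.5-fold higher number from compound 2 to compound 3 (0.18 log units; within the scatter) and so chloro and trifluoromethyl cannot be told apart here on these numbers. Comparing the whole terminal groups gives a 1.0-fold lower number from compound 1 to compound 3 (0.01 log units; within the scatter) and so 3,4-dichlorophenyl and 3-(trifluoromethyl)phenyl on the amide-type nitrogen also cannot be told apart, leaving compounds 1, 2 and 3 without a separation in this series. Nothing on record bears on why these numbers lie so close.

From the compounds shown here alone, what an amine, a carboxylic acid or a longer chain at this position would give in this assay stays open. Also open, going by these compounds, is whether any exchange on this terminal phenyl can produce a step beyond the scatter.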